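Sulfonamide nitrogen change on the brominated core

The source may report more compounds than this note shows. Statements on the series, on what has been measured and on what is new or still open speak of the compounds shown alone.

Two members of this series have been measured. Compound 1 `CN(C)S(=O)(=O)Cc1noc2ccccc12` gives 37 mg/kg in a functional assay on the whole organism (strain STD-dd) with Mus musculus as the target, in the maximal electroshock model, with a stated time of 2 h; on this read-out higher numbers stand for an effect only at larger amounts of compound and lower numbers for an effect already at smaller amounts. Compound 2 `CC(C)NS(=O)(=O)Cc1noc2ccc(Br)cc12` gives 22 mg/kg in this assay; on the numbers alone it sits at the lower end of the two, but the gap to compound 1 lies within the usual scatter, so no order between them can be claimed. Compound 3 `CN(C)S(=O)(=O)Cc1noc2ccc(Br)cc12` has not yet been measured. The change from compound 2 to compound 3 is dimethylamino in place of isopropylamino on a sulfonyl sulfur. Among the measured compounds shown here, no directly comparable step between measured compounds exists; compound 1 and compound 3 share the dimethylamino group and differ only in the bromine, and compound 1 gives 37 mg/kg. The step of a 1.3-fold higher number from compound 2 to compound 3 (0.10 log units; within the scatter) is expected to be small, within the scatter, with no clear direction. Compound 3 is therefore estimated at 28 mg/kg, with a range of 14 mg/kg to 56 mg/kg.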

Compound 3, dose for half-maximal effect: 45 mg/kg
Estimate against measurement, compound 3: 1.6-fold (0.21 log units) below; the measured number falls inside the stated range.
By their numbers in this assay, from the lowest: compounds 2, 1 and 3 (each within the scatter of the next, the first and the last beyond it).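

Among the compounds shown here, on the brominated core, the sulfonamide nitrogen is the first place where a single change can be read: in this assay, dimethylamino in place of isopropylamino on a sulfonyl sulfur gives a 2.0-fold higher number from compound 2 to compound 3 (0.31 log units; beyond the scatter), a modest step just beyond the scatter. Bromo in place of hydrogen on an aromatic carbon, with dimethylamino held constant, gives a 1.2-fold higher number from compound 1 to compound 3 (0.09 log units; within the scatter), so this pair shows no readable effect of the bromine. No supporting data bear on why the nitrogen change shifts the number.

On these data alone, whether the nitrogen step holds on the core without bromo remains open. As far as these compounds go, it is also open whether the step follows the loss of the hydrogen-bond donor or the change of alkyl groups, which methylamino, diethylamino or an unsubstituted amino group on the same sulfur could help separate.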